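Ester substituent step from compound 2 to compound 3

This account rests on a few compounds, and the source may have more. Where it says the series, first, only, none or still open, it means among the compounds named here.

In a functional assay on isolated protein for inhibition of Glucose-dependent insulinotropic receptor (Rattus norvegicus), read by HTRF and cAMP accumulation (on this read-out lower numbers stand for an effect already at smaller amounts and higher numbers for an effect only at larger amounts of compound), compound 2 `Cc1nc(S(C)(=O)=O)ccc1Oc1ncnc(OC2CCN(C(=O)O[C@H](C)C(F)(F)F)CC2)c1F` gives 110 nM and compound 1 `Cc1nc(S(C)(=O)=O)ccc1Oc1ncnc(OC2CCN(C(=O)OC(C)(C)CF)CC2)c1F` gives 138 nM. Of the two numbers shown compound 2 carries the smaller, yet a 1.3-fold lower number from compound 1 to compound 2 (0.10 log units; within the scatter) is within the scatter, so the pair is level. Compound 3 `CCC1(OC(=O)N2CCC(Oc3ncnc(Oc4ccc(S(C)(=O)=O)nc4C)c3F)CC2)CC1` differs from compound 2 by 1-ethylcyclopropyl in place of 1-(trifluoromethyl)ethyl on an oxygen next to a carbonyl group. Among the compounds with values here, only the step from compound 1 to compound 2 bears on this oxygen, and it was small. A further exchange there is therefore expected to give no step beyond the scatter in this assay. Compound 3 is estimated at 120 nM in this assay, range 50 nM to 300 nM. This expected value means a 1.1-fold higher number from compound 2 to compound 3 (0.04 log units; within the scatter).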

Compound 3, half-maximal effective concentration: 333 nM
Compound 3: middle estimate off by 2.8-fold (0.44 log units), on the low side; the whole stated range lies below it.
By their numbers in this assay, from the lowest: compounds 2 and 1 (each within the scatter of the next); then compound 3.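

This oxygen substituent is not indifferent in this assay: unlike the earlier exchange, both new steps lie beyond the scatter, with a 3.0-fold higher number from compound 2 to compound 3 (0.48 log units; beyond the scatter) and a 2.4-fold higher number from compound 1 to compound 3 (0.38 log units; beyond the scatter). Among the three compounds, only 1-ethylcyclopropyl combines a three-membered ring with the absence of fluorine, and only that group gives a step of this kind. No available measurement accounts for this change.

The ring and the loss of fluorine remain inseparable in these compounds. Open, from the compounds shown here alone, is how 1-(trifluoromethyl)cyclopropyl or a non-fluorinated tert-butyl group would compare.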